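Working notes: chain substituent series, compound 3 to compound 4

This account rests on a few compounds, and the source may have more. Where it says the series, first, only, none or still open, it means among the compounds named here.

Three analogues sharing one core have been measured in a functional assay (trachea) with Cavia porcellus as the target; on this read-out higher numbers stand for weaker inhibition and lower numbers for stronger inhibition. Compound 1 `CCCn1nc(-c2cccnc2)c2ccccc2c1=O` gives 3160 nM. Compound 2 `CCCCn1nc(-c2cccnc2)c2ccccc2c1=O` gives 2290 nM, and the step of a 1.4-fold lower number from compound 1 to compound 2 (0.14 log units; within the scatter). Compound 3 `CC(=O)OCCn1nc(-c2cccnc2)c2ccccc2c1=O` gives 9770 nM, the highest number of the three: a 3.1-fold higher number from compound 1 to compound 3 (0.49 log units; beyond the scatter) and a 4.3-fold higher number from compound 2 to compound 3 (0.63 log units; beyond the scatter).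

Compound 4 `CC(C)NC(=O)CCCn1nc(-c2cccnc2)c2ccccc2c1=O` is not yet measured. Its structure differs from compound 3 by (isopropylcarbamoyl)methyl in place of acetoxy on a saturated chain carbon, two bonds along the chain from an aromatic nitrogen. For the measured compounds named here, the only measured steps at this place are the two that bring in acetoxy, and both raised the number modestly, so removing acetoxy is the part of the change with some precedent; the entering (isopropylcarbamoyl)methyl group has no counterpart among the measured compounds, and a longer chain at this place has not been tested. The number for compound 4 is therefore expected to fall back somewhat toward those of compounds 1 and 2, with wide uncertainty: the expected step is a 2.4-fold lower number from compound 3 to compound 4 (0.39 log units; beyond the scatter). Compound 4 is estimated at 4000 nM, in the range 1000 nM to 16000 nM.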

Compound 4, half-maximal inhibitory concentration: 64600 nM
Estimate against measurement, compound 4: 16-fold (1.21 log units) below; the measured number lies above the stated range.
By their numbers in this assay, from the lowest: compounds 2 and 1 (each within the scatter of the next); then compound 3; then compound 4.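

The (isopropylcarbamoyl)methyl group takes the number past that of acetoxy rather than back toward the plain chains, with a 6.6-fold higher number from compound 3 to compound 4 (0.82 log units; beyond the scatter) in this assay, so removing acetoxy does not by itself restore the lower numbers. Against the plain chains the change is large, with a 20-fold higher number from compound 1 to compound 4 (1.31 log units; beyond the scatter) and a 28-fold higher number from compound 2 to compound 4 (1.45 log units; beyond the scatter), which shows that this position, indifferent to the one methyl between compound 1 and compound 2, responds strongly to the chain's end group. Nothing available bears on the origin of this rise.

The compounds shown do not separate the contribution of the amide from that of chain length, as compound 4 differs from compound 3 in both. On these data alone, a longer plain alkyl chain, a primary amide and a carboxylic acid at this place remain open, as does the role of the isopropyl group.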